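Azole nitrogen count on the ketone-linked bicycle

A few compounds are considered here, and "the series" means these few. Any claim that something is new, unique, unknown or untested is made for them only; others in the source may bear on it.

Measured so far:
compound 1 `CCCCCCCCc1ccc(OCC(=O)Cn2ncc3cccnc32)cc1` — 1600 nM
compound 2 `CCCCCCCCc1ccc(OCC(=O)Cn2ccc3ncccc32)cc1` — > 10000 nM

Among the measured compounds shown here, in an assay on microsomes from brain for inhibition of Fatty-acid amide hydrolase 1 (Rattus norvegicus), read by fluorescence and HPLC, with a stated time of 60 min (a lower number here means a stronger inhibitor, a higher number a weaker inhibitor), compound 1 gives 1600 nM, the only actual number in the set. Compound 2 sits at the limit of > 10000 nM in this assay, at which 1 of the 2 values shown sits, a limit rather than a number. Compound 3 `CCCCCCCCc1ccc(OCC(=O)Cn2nnc3ncccc32)cc1` is not yet measured; it differs from compound 1 by a group of 9 heavy atoms (5 carbon, 4 nitrogen; one five-membered aromatic ring with 3 hetero atoms, one six-membered aromatic ring with 1 hetero atom) in place of a group of 9 heavy atoms (6 carbon, 3 nitrogen; one five-membered aromatic ring with 2 hetero atoms, one six-membered aromatic ring with 1 hetero atom), on a saturated chain carbon bound to a carbonyl carbon. For the measured compounds named here, the only measured step at this position is an at least 6.2-fold higher number from compound 1 to compound 2 (0.79 log units; beyond the scatter), where the five-membered ring lost a hetero atom; compound 3 gains one instead, so that step does not cover it directly. Compound 3 is expected near 1000 nM, between 300 nM and 4000 nM. The estimated step of a 1.6-fold lower number from compound 1 to compound 3 (0.20 log units; within the scatter) is expected to stay within the scatter.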

Compound 3, half-maximal inhibitory concentration: 49 nM
Beside the measured number, compound 3's estimate is 20-fold (1.31 log units) above it; the measured number lies below the stated range.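

At the saturated chain carbon bound to a carbonyl carbon, the group with 3 hetero atoms in its five-membered aromatic ring gives a 33-fold lower number from compound 1 to compound 3 (1.51 log units; beyond the scatter) in this assay. Across these compounds, the number falls as hetero atoms in that ring rise, over a span of an at least 200-fold lower number from compound 2 to compound 3 (2.30 log units; beyond the scatter). The span rests on a limit for compound 2, not a number: the limit of > 10000 nM in this assay, at which 1 of the 3 values shown sits.

Each hetero atom count appears in one arrangement only, so count and arrangement remain unseparated. Going by these compounds, whether the step survives with a hexyl chain in place of the octyl chain also remains open.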